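Fluorine on the core and cytotoxicity in MT4 cells

The source may report more compounds than this note shows. Statements on the series, on what has been measured and on what is new or still open speak of the compounds shown alone.

Compound 1, `Cc1cc(C)cc(Cn2c(=O)[nH]c3ccc(Cl)cc32)c1`, gives 8900 nM in an ADME assay on MT4 cells (Homo sapiens) for cytotoxicity; on this read-out higher numbers stand for lower toxicity in this test and lower numbers for higher toxicity in this test.
Compound 2, `O=c1[nH]c2ccc(Cl)cc2n1Cc1cc(F)cc(F)c1`, reaches only a limit of the test in this assay, > 424000 nM, not a number.
Compound 3, `Cc1cc(C)cc(Cn2c(=O)[nH]c3cc(F)c(Cl)cc32)c1`, reaches only a limit of the test in this assay, > 410000 nM, not a number.

Compound 3 differs from compound 1 by fluoro in place of hydrogen on an aromatic carbon. The step is an at least 46-fold higher number from compound 1 to compound 3 (1.66 log units; beyond the scatter), with compound 3 standing at the limit of > 410000 nM in this assay, at which 1 of the 3 values shown sits. Compound 4, `O=c1[nH]c2cc(F)c(Cl)cc2n1Cc1cc(F)cc(F)c1`, is not yet measured and differs from compound 2 by fluoro in place of hydrogen on an aromatic carbon, the same change at the same place. The difference between the two cores of compound 1 and compound 2 is not broken down here. Because compound 2 already stands at the limit of > 424000 nM in this assay, at which 1 of the 3 values shown sits, the change to compound 4 is expected to give a step that the limit leaves unreadable from compound 2 to compound 4. Compound 4 is therefore estimated at 450000 nM, most likely reported again only as a limit, between 200000 nM and 1000000 nM.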

Compound 4, half-maximal cytotoxic concentration: > 400000 nM
Compound 4 was reported as a limit; the forecaster's own chance of this, stated with the estimate: 85%; the middle value is on the limit's open side.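

Compound 2 and compound 4 are both reported only as limits in this assay, and the step between them cannot be read. On these data alone, whether fluoro in place of hydrogen changes the number starting from compound 2 stays open.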